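This account rests on a few compounds, and the source may have more. Where it says the series, first, only, none or still open, it means among the compounds named here.

Compounds measured in this series:
compound 1 `O=c1cc(CC(O)(COCc2ccccc2)COCc2ccccc2)[nH]c(=O)[nH]1` — > 100000 nM
compound 2 `O=c1cc(CC(COCc2ccccc2)COCc2ccccc2)[nH]c(=O)[nH]1` — > 100000 nM
compound 3 `O=c1cc(CC(O)COCc2ccccc2)[nH]c(=O)[nH]1` — > 100000 nM

Each of these values in a functional assay on HepG2 cells (Homo sapiens) for antiproliferative activity, read by MTT assay, with a stated time of 72 h (a higher number here means a weaker inhibitor, a lower number a stronger inhibitor), is a limit of the assay, not a number. For compound 3 the figure is such a limit, as is the case at the limit of > 100000 nM in this assay, at which 3 of the 3 values shown sit. The steps a step that the two limits leave unreadable from compound 1 to compound 2, a step that the two limits leave unreadable from compound 1 to compound 3 and a step that the two limits leave unreadable from compound 2 to compound 3 therefore cannot be read in size or direction.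

Compound 4 `Cc1c(CC(O)COCc2ccccc2)[nH]c(=O)[nH]c1=O` differs from compound 3 by methyl in place of hydrogen on an aromatic carbon. For the measured compounds named here, none of the measured steps touches this aromatic carbon, and none of them is readable, so no step of a known size bears on this change. Compound 4 is expected to remain at the limit, an estimate of 150000 nM with a range of 50000 nM to 500000 nM, meaning an expected step that the limit leaves unreadable from compound 3 to compound 4.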

Compound 4, half-maximal inhibitory concentration: > 100000 nM
Compound 4 gave a limit, no number (the forecaster's own chance of this, stated with the estimate: 85%); the middle value is on the limit's open side.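

For the compounds shown here, compound 3 and compound 4 both give a limit rather than a number, so no step between them can be read in size or direction: the limit of > 100000 nM in this assay, at which 4 of the 4 values shown sit. The compounds shown leave open what any of these changes does to activity in this assay.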